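From phenoxy to (4-acetylphenyl)amino on a carbonyl carbon

The source may hold more compounds than are shown below. What is called first, only, known or untested is meant among the compounds shown, and "the series" means these compounds.

Measured in a functional assay on HUVEC cells (Homo sapiens) for inhibition (on this read-out lower numbers stand for stronger inhibition and higher numbers for weaker inhibition), so far:
compound 1 `CN(c1ccc(NC(=O)Oc2ccccc2)cc1)c1ccnc(Nc2cccc(CS(C)(=O)=O)c2)n1` gives 224 nM
compound 2 `CN(c1ccc(NC(=O)Nc2cc(C(F)(F)F)ccc2F)cc1)c1ccnc(Nc2cccc(S(N)(=O)=O)c2)n1` gives 10 nM
compound 3 `CN(c1ccc(NC(=O)Nc2cc(C(F)(F)F)ccc2F)cc1)c1ccnc(Nc2ccc(S(N)(=O)=O)cc2)n1` gives 8 nM

Of the three, compound 1 has the highest number, and its 224 nM lies beyond the scatter from both others. Compound 4 `CC(=O)c1ccc(NC(=O)Nc2ccc(N(C)c3ccnc(Nc4cccc(CS(C)(=O)=O)c4)n3)cc2)cc1` keeps the rest of compound 1 and changes one place: (4-acetylphenyl)amino in place of phenoxy on a carbonyl carbon. In short, (4-acetylphenyl)amino stands in place of phenoxy on a carbonyl carbon.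

Among the compounds with values here, no measured step covers this change. The only one available, a 1.3-fold lower number from compound 2 to compound 3 (0.10 log units; within the scatter), lies at another place in the structure and says nothing about the carbonyl side. The evidence is indirect. Compound 2 at 10 nM and compound 3 at 8 nM also have an arylamino group on the carbonyl carbon, but a different one, and both differ from compound 1 elsewhere too, so the gap to compound 1 cannot be assigned to that group alone. A move to a lower number is therefore expected in this assay, though probably a smaller one than that gap. The expected change is a 6.4-fold lower number from compound 1 to compound 4 (0.81 log units; beyond the scatter). Compound 4 is estimated at 35 nM, with an expected range from 8 nM to 150 nM.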

Compound 4, half-maximal inhibitory concentration: 2 nM
Estimate against measurement, compound 4: 18-fold (1.24 log units) above, outside the stated range (below it).
By their numbers in this assay, from the lowest: compound 4; then compounds 3 and 2 (each within the scatter of the next); then compound 1.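

In this assay the carbonyl side of the series now has a step of its own, a 110-fold lower number from compound 1 to compound 4 (2.05 log units; beyond the scatter). Only this one place differs, and the whole of that large step belongs to the change from phenoxy to (4-acetylphenyl)amino on a carbonyl carbon. Position and size are thus tied together for the first time: the only earlier step between compounds that differ in one place, at the sulfamoylphenyl group, stayed within the scatter, whereas this position moves the number far beyond it. Within the data shown here, the single change brings in the amino nitrogen in place of the oxygen and also the acetyl group, and no measured data here say which part carries the step or give any reason for its size.

Open, on these data alone, is whether plain phenylamino, without the acetyl group, would keep the step, and whether a carboxylic acid or a nitrile in place of the acetyl group would do the same. Also open, as far as these compounds go, is whether the same change on the carbonyl carbon gives a step of similar size when 3-sulfamoylphenyl or 4-sulfamoylphenyl stands on the other side of the shared core.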